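Extending a Methoxy Chain on Two Related Cores

This account rests on a few compounds, and the source may have more. Where it says the series, first, only, none or still open, it means among the compounds named here.

Compound 1 `COC/C=C/c1cccc(N(Cc2ccc(/C=C/C(=O)OC(C)(C)C)cc2)C(=O)C2CCCCC2)c1` and compound 2 `CCOC/C=C/c1cccc(N(Cc2ccc(/C=C/C(=O)OC(C)(C)C)cc2)C(=O)C2CCCCC2)c1` share one core; compound 3 `COC/C=C/c1ccc(CN(C(=O)C2CCCCC2)c2cccc(/C=C/C(=O)OC)c2)cc1` and compound 4 `CCOC/C=C/c1ccc(CN(C(=O)C2CCCCC2)c2cccc(/C=C/C(=O)OC)c2)cc1` share another, and the difference between the two cores is not broken down here. In an assay on isolated protein with Bile acid receptor (Homo sapiens) as the target (a lower number here means that less compound is needed, a higher number that more compound is needed for the effect), compound 1 gives 243 nM, and compound 2 gives 220 nM. The change between them, (methyl in place of hydrogen on a saturated chain carbon bound to an oxygen on a saturated carbon), made a step of a 1.1-fold lower number from compound 1 to compound 2 (0.04 log units; within the scatter). In this assay compound 3 gives 233 nM. Compound 4 carries the same change, (methyl in place of hydrogen on a saturated chain carbon bound to an oxygen on a saturated carbon), on the other core. Among the measured compounds shown here, for compound 4 a similarly small step is expected, a 1.1-fold lower number from compound 3 to compound 4 (0.03 log units; within the scatter), because a 1.1-fold lower number from compound 1 to compound 2 (0.04 log units; within the scatter) stayed within the usual scatter, and only two compounds show this change. Compound 4 is therefore estimated at 215 nM, with a likely range from 110 nM to 430 nM.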

Compound 4, half-maximal effective concentration: 198000 nM
Estimate against measurement, compound 4: 920-fold (2.96 log units) below; the measured number lies above the stated range.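

In this assay, the change from methoxy to ethoxy did not carry over between the two cores: on the second core it gave an 850-fold higher number from compound 3 to compound 4 (2.93 log units; beyond the scatter). Set beside the first core, the two steps clearly differ: the same change on two cores in this assay, a 1.1-fold lower number (0.04 log units; within the scatter) from compound 1 to compound 2 and an 850-fold higher number (2.93 log units; beyond the scatter) from compound 3 to compound 4, 940-fold (2.97 log units) apart, beyond the scatter of two such steps. The outcome of this small change therefore depends on the core in these two pairs, but two pairs do not tell which difference between the cores matters, nor how any other change would carry over.

The compounds shown leave open how a longer chain such as propoxy, or a hydroxyl in place of the methoxy, would behave on each core. They also leave open whether the sharp rise begins with ethoxy or extends to other groups at this place.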